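A Benzyl Ether in Place of a Dichlorobenzyl Ether

The source may report more compounds than this note shows. Statements on the series, on what has been measured and on what is new or still open speak of the compounds shown alone.

In a functional assay on PC-3 cells (Homo sapiens) for cytotoxicity, read by MTT assay, with a stated time of 72 h (on this read-out higher numbers stand for weaker inhibition and lower numbers for stronger inhibition), compound 1 `O=C(/C=C/c1ccccc1)NNC(=O)c1ccccc1O` gives 40900 nM. For compound 2 `COCOc1cc(/C=C/C(=O)OCC(=O)Nc2ccc(OC)cc2)ccc1OCc1ccccc1` the assay reports only a limit, > 200000 nM. For compound 3 `COc1ccc(NC(=O)COC(=O)/C=C/c2cc(OC)c(OCc3ccc(Cl)c(Cl)c3)c(OC)c2)cc1` the result is likewise only a limit, > 200000 nM. Compound 3 thus sits at the limit of > 200000 nM in this assay, at which 2 of the 3 values shown sit, with no numbered value to place it against compound 1. Compound 4 `COc1ccc(NC(=O)COC(=O)/C=C/c2cc(OC)c(OCc3ccccc3)c(OC)c2)cc1` differs from compound 3 by phenyl in place of 3,4-dichlorophenyl on a saturated chain carbon bound to an oxygen on an aromatic ring. Among the measured compounds shown here, no measured step covers this change, and compound 3 offers only a limit as the starting point. The step of a number no higher from compound 3 to compound 4 (the limit leaves the size open) is expected to stay within the scatter, most likely ending again at the limit rather than at a numbered value. Compound 4 is therefore estimated at 200000 nM, with a range from 60000 nM to 400000 nM.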

Compound 4, half-maximal inhibitory concentration: > 200000 nM
Compound 4 ended at the assay's limit; the forecaster's own chance of this, stated with the estimate: 65%; the middle value sits exactly at the limit.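

Compound 3 and compound 4 both give only a limit, and no step between them can be read: the limit of > 200000 nM in this assay, at which 3 of the 4 values shown sit.

The compounds shown leave open whether phenyl in place of 3,4-dichlorophenyl changes the activity at all.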